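Swapping a methyl for bromine on the cinnamoyl aryl ring

The source may hold more compounds than are shown below. What is called first, only, known or untested is meant among the compounds shown, and "the series" means these compounds.

Measured so far:
- compound 1 `Cc1ccc(/C=C/C(=O)NNC(=O)c2ccc3c(c2)OCCO3)cc1`: 1050 nM
- compound 2 `COc1ccc(/C=C/C(=O)NNC(=O)c2ccc3c(c2)OCCO3)cc1`: 930 nM
- compound 3 `O=C(/C=C/c1ccccc1Cl)NNC(=O)c1ccc2c(c1)OCCO2`: 4880 nM

All three share the same core and differ only in the aryl group on the double-bonded chain. In a functional assay on cells (Cancer cell lines, Homo sapiens) for inhibition, read by MTT assay, with a stated time of 48 h (on this read-out higher numbers stand for weaker inhibition and lower numbers for stronger inhibition), compound 1 stands second highest of the three numbers; compound 2 sits closest, with a 1.1-fold lower number from compound 1 to compound 2 (0.05 log units; within the scatter), a change that stays inside the usual scatter. Compound 3 stands furthest away, with a 4.6-fold higher number from compound 1 to compound 3 (0.67 log units; beyond the scatter), and compound 2 shows the same trend toward compound 3, with a 5.2-fold higher number from compound 2 to compound 3 (0.72 log units; beyond the scatter).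

The unmeasured compound 4 `O=C(/C=C/c1cccc(Br)c1)NNC(=O)c1ccc2c(c1)OCCO2` takes the same route away from compound 1: 3-bromophenyl in place of 4-methylphenyl on a double-bonded chain carbon bound to a double-bonded chain carbon. Within the data shown here, the only steps that bear on a halogen-bearing phenyl in place of a substituted phenyl are those to compound 3, and both were modest moves toward weaker inhibition. Since 3-bromophenyl is not 2-chlorophenyl, the step cannot be copied directly, but the direction is the best available guide. Compound 4 is therefore expected to give a somewhat higher number than compound 1 in this assay, estimated as a 2.1-fold higher number from compound 1 to compound 4 (0.32 log units; beyond the scatter). The expected value for compound 4 is 2200 nM, with a range from 900 nM to 5500 nM.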

Compound 4, half-maximal inhibitory concentration: 3330 nM
Beside the measured number, compound 4's estimate is 1.5-fold (0.18 log units) below it, and the stated range covers the measured number.
By their numbers in this assay, from the lowest: compounds 2 and 1 (each within the scatter of the next); then compounds 4 and 3 (each within the scatter of the next).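

In this assay, a second halogen-bearing phenyl group on this double-bonded chain carbon also gives weaker inhibition, with a 3.2-fold higher number from compound 1 to compound 4 (0.50 log units; beyond the scatter) and a 3.6-fold higher number from compound 2 to compound 4 (0.55 log units; beyond the scatter). Among these compounds, until now, this move rested on the 2-chlorophenyl group of compound 3 alone; now, among the four compounds, both halogen-bearing groups give higher numbers than 4-methylphenyl and 4-methoxyphenyl, and no compound goes against this. The two halogen-bearing groups cannot be told apart, with a 1.5-fold lower number from compound 3 to compound 4 (0.17 log units; within the scatter), so exchanging 2-chlorophenyl for 3-bromophenyl, which changes both the halogen and its place on the ring, leaves the number within the usual scatter.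

Nothing measured here explains why these groups give weaker inhibition. The compounds shown leave open whether the halogen itself or its place on the ring matters more, as the two change together from compound 3 to compound 4, and how a phenyl ring carrying an amine or a carboxylic acid would behave on this same chain carbon.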